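Pyrazine Ring in Place of Pyridine on the Ring Nitrogen

The compounds below may be only part of what the source reports. "The series", "measured", "known", "first", "only" and "open" are said of these compounds alone.

Three compounds sharing one core were measured in a functional assay on A-375 cells (Homo sapiens) for antiproliferative activity, read by CCK-8 assay, with a stated time of 72 h, tested at 2 uM; a lower number here means a weaker effect, a higher number a stronger effect of the compound at the concentration tested. Compound 1 `COc1ccc(N2CCN(C(=S)SCc3ccc(C(=O)Nc4ccccc4N)cc3)CC2)cc1` gives 28.1%, compound 2 `Nc1ccccc1NC(=O)c1ccc(CSC(=S)N2CCN(c3ncccn3)CC2)cc1` gives 24%, and compound 3 `Nc1ccccc1NC(=O)c1ccc(CSC(=S)N2CCN(c3ccncc3)CC2)cc1` gives 85.7%, the highest of the three. The nearest other number is spanned by a number 57.6 percentage points higher from compound 1 to compound 3 (beyond the scatter), the furthest by a number 61.7 percentage points higher from compound 2 to compound 3 (beyond the scatter). Compound 4 `Nc1ccccc1NC(=O)c1ccc(CSC(=S)N2CCN(c3cnccn3)CC2)cc1` has not yet been measured and differs from compound 3 by pyrazin-2-yl in place of pyridin-4-yl on an amine nitrogen in a ring. Both steps ending at compound 3 bear on this change: a number 57.6 percentage points higher from compound 1 to compound 3 (beyond the scatter) and a number 61.7 percentage points higher from compound 2 to compound 3 (beyond the scatter) show that the group on this ring nitrogen matters greatly, and pyrimidin-2-yl in compound 2 gave a low number. Since the entering ring likewise carries two hetero atoms, a drop is expected, of uncertain size. The step from compound 3 is estimated as a number 40.7 percentage points lower from compound 3 to compound 4 (beyond the scatter). Compound 4 is therefore expected to give about 45%, between 18% and 78%.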

Compound 4, a percentage reported as inhibition, at one concentration (the size of the read-out at that concentration, not a potency): 29.1%
Compound 4: middle estimate off by 15.9 percentage points, on the high side; the measured number falls inside the stated range.
By their numbers in this assay, from the lowest: compounds 2, 1 and 4 (each within the scatter of the next); then compound 3.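

The step of a number 56.6 percentage points lower from compound 3 to compound 4 (beyond the scatter) shows that swapping pyridin-4-yl for pyrazin-2-yl at this ring nitrogen is enough to lose most of the effect. With a number 5.1 percentage points higher from compound 2 to compound 4 (within the scatter) and a number 1 percentage points higher from compound 1 to compound 4 (within the scatter) both within the scatter, pyrazin-2-yl, pyrimidin-2-yl and 4-methoxyphenyl cannot be told apart here, so pyridin-4-yl alone stands out. Counting ring hetero atoms does not sort these compounds, as compound 1 has a ring without any and still sits with compounds 2 and 4.

On these data alone, whether pyridin-3-yl or a pyridin-4-yl ring carrying an amine would keep the high number remains open. No measurement available here explains why pyridin-4-yl differs from the other groups.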